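A few compounds are considered here, and "the series" means these few. Any claim that something is new, unique, unknown or untested is made for them only; others in the source may bear on it.

Measured so far in an ADME assay on HFF cells (Homo sapiens) for cytotoxicity, read by XTT assay, with a stated time of 8 days; on this read-out higher numbers stand for lower toxicity in this test and lower numbers for higher toxicity in this test:
- compound 1, `CC(=O)OC[C@H]1O[C@@H](n2c(Br)nc3c(Cl)c(Cl)c(Cl)cc32)[C@H](OC(C)=O)[C@@H]1OC(C)=O`: 27900 nM
- compound 2, `OC[C@H]1O[C@@H](n2c(Br)nc3cc(Cl)c(Cl)cc32)[C@H](O)[C@@H]1O`: 314000 nM

Compound 1 stands at the lowest of the two numbers; the nearest is compound 2, whose half-maximal cytotoxic concentration is higher by a margin beyond the scatter. Among the compounds with values here, compound 2 differs from compound 1 in more than one place, so no single step is given for that pair, and its two values are read only as they stand.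

Compound 3, `CC(=O)OC[C@H]1O[C@@H](n2c(Cl)nc3c(Cl)c(Cl)c(Cl)cc32)[C@H](OC(C)=O)[C@@H]1OC(C)=O`, has not yet been measured in this assay. Against compound 1 the change is chloro in place of bromo on an aromatic carbon — chloro in place of bromo on an aromatic carbon of the shared core, with the acetylated sugar kept unchanged. An exchange of this kind is expected to leave the number close to where compound 1 stands: the step of a 1.3-fold higher number from compound 1 to compound 3 (0.10 log units; within the scatter) is expected to lie within the scatter, with no set direction. Compound 3 is therefore estimated at 35000 nM, in the range 12000 nM to 100000 nM.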

Compound 3, half-maximal cytotoxic concentration: 66700 nM
For compound 3 the middle estimate is 1.9-fold (0.28 log units) below the measured one, within the range that was stated.
By their numbers in this assay, from the lowest: compound 1; then compound 3; then compound 2.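

In this assay the aromatic carbon between two ring nitrogen atoms is not a silent position: chloro in place of bromo, with the acetylated sugar and the rest of the shared core unchanged, gives a 2.4-fold higher number from compound 1 to compound 3 (0.38 log units; beyond the scatter) and this modest step lies beyond the scatter. Within the data shown here, this is the first reading that can be tied to one place, and it shows that exchanging one halogen for the other at this carbon is enough to move the number. No available information bears on what lies behind the step.

Only bromo and chloro are shown at this carbon, so it stays open how an amine, a methyl group or a hydrogen would read there. Also open, from the compounds shown here alone, is whether the same exchange gives a similar step on a core carrying the free, unacetylated sugar.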